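This account rests on a few compounds, and the source may have more. Where it says the series, first, only, none or still open, it means among the compounds named here.

In a functional assay on cells (Homo sapiens) for cytotoxicity, read by MTT assay, with a stated time of 24 h (a higher number here means a weaker inhibitor, a lower number a stronger inhibitor), three imines have been measured: compound 1 (`CCCCCCCCCCCCCCNC(=O)[C@H](CO)/N=C/c1ccccc1OC`) gives 12500 nM, compound 2 (`CCCCCCCCCCCCCCNC(=O)[C@H](CO)/N=C/c1ccccc1`) gives 7670 nM, and compound 3 (`CCCCCCCCCCCCCCNC(=O)[C@H](CO)/N=C/c1cccc(Cl)c1`) gives 24100 nM. Compound 3 cannot be told apart from one of the others but stands clear of the other. The two steps that reach it are a 1.9-fold higher number from compound 1 to compound 3 (0.29 log units; within the scatter) and a 3.1-fold higher number from compound 2 to compound 3 (0.50 log units; beyond the scatter), and only the second passes the scatter, by a modest margin.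

Compound 4 (`CCCCCCCCCCCCCCNC(=O)[C@H](CO)NCc1ccccc1Cl`) brings a new change: a group of 9 heavy atoms (7 carbon, 1 nitrogen, 1 chlorine; one six-membered aromatic ring of carbon only) in place of a group of 9 heavy atoms (7 carbon, 1 nitrogen, 1 chlorine; one six-membered aromatic ring of carbon only), on a saturated chain carbon bound to a carbonyl carbon and a saturated chain carbon. The entering group is (2-chlorobenzyl)amino. Among the measured compounds shown here, no measured step replaces a group of this kind, so the evidence is indirect. The closest guides are the changes on the aromatic ring, such as a 1.6-fold lower number from compound 1 to compound 2 (0.21 log units; within the scatter), which stays within the scatter, and the larger 3.1-fold higher number from compound 2 to compound 3 (0.50 log units; beyond the scatter). With only these to go on, no step beyond the scatter is expected, though the uncertainty is wide. The expected change is a 1.7-fold lower number from compound 3 to compound 4 (0.24 log units; within the scatter). For compound 4 the estimated value is 14000 nM, with an expected range from 5000 nM to 32000 nM.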

Compound 4, half-maximal inhibitory concentration: 43700 nM
Compound 4: middle estimate off by 3.1-fold (0.49 log units), on the low side; measured number outside the range, above it.
By their numbers in this assay, from the lowest: compounds 2, 1, 3 and 4 (each within the scatter of the next, the first and the last beyond it).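

At this saturated chain carbon bound to a carbonyl carbon and a saturated chain carbon, the entering (2-chlorobenzyl)amino group has no double bond outside the ring and adds a hydrogen-bond donor, yet this assay shows a 1.8-fold higher number from compound 3 to compound 4 (0.26 log units; within the scatter) and so does not separate this group from the one it replaces. The same position does separate it from the other two imines, with a 5.7-fold higher number from compound 2 to compound 4 (0.76 log units; beyond the scatter) and a 3.5-fold higher number from compound 1 to compound 4 (0.54 log units; beyond the scatter) both passing the scatter. So this swap brings no lower number against any imine shown, and no supporting data explain the result.

Still open, from the compounds shown here alone, is how much of the difference belongs to the chlorine and how much to the lost double bond. A plain benzylamino group, with no chlorine, could be set against compound 2 to separate the two.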